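The compounds below may be only part of what the source reports. "The series", "measured", "known", "first", "only" and "open" are said of these compounds alone.

Among the measured compounds shown here, compound 1 `COc1ccc(-c2coc3cc(OCCCSC(=S)N4CCCC4)ccc3c2=O)cc1` is one of two compounds measured in a functional assay on PC-3 cells (Homo sapiens) for inhibition, read by MTT assay, with a stated time of 48 h; on this read-out higher numbers stand for weaker inhibition and lower numbers for stronger inhibition: compound 1 gives 19400 nM, while compound 2 `COc1ccc(-c2coc3cc(OCCCSC(=S)N4CCN(c5ccccn5)CC4)ccc3c2=O)cc1` gives 17400 nM. For the measured compounds named here, the single measured step, a 1.1-fold lower number from compound 1 to compound 2 (0.05 log units; within the scatter), changed only the amine on the thiocarbonyl carbon and does not bear on the change to compound 3. Compound 3 `COc1ccc(-c2coc3cc(OCCBr)ccc3c2=O)cc1` differs from compound 1 in one bromine atom in place of a group of 9 heavy atoms (6 carbon, 1 nitrogen, 2 sulfur; one five-membered non-aromatic ring with 1 hetero atom), on a saturated chain carbon, two bonds along the chain from an oxygen on an aromatic ring. Going by the values given here, with no measured step touching this part of the chain, a reading near or weaker than compound 1 is expected, an estimated step of a 1.3-fold higher number from compound 1 to compound 3 (0.11 log units; within the scatter). Compound 3 is therefore estimated at 25000 nM, with a range from 8000 nM to 70000 nM.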

Compound 3, half-maximal inhibitory concentration: 41900 nM
Beside the measured number, compound 3's estimate is 1.7-fold (0.22 log units) below it; the measured number falls inside the stated range.
By their numbers in this assay, from the lowest: compounds 2 and 1 (each within the scatter of the next); then compound 3.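

Where the change of amine on the thiocarbonyl carbon left the number within the scatter, replacing the whole group of 9 heavy atoms with bromo gives a 2.2-fold higher number from compound 1 to compound 3 (0.33 log units; beyond the scatter) in this assay. This saturated chain carbon is thus the first place in the series where a change moves the number beyond the scatter, though only modestly. Nothing available here explains this shift.

From the compounds shown here alone, whether an amine or a hydroxyl group at this place would read nearer compound 1 or compound 3 remains open. So does the effect of a longer chain.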